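Replacing the ether chain of a sulfonamide with a branched triamine

The source may hold more compounds than are shown below. What is called first, only, known or untested is meant among the compounds shown, and "the series" means these compounds.

Measured so far in a functional assay on HEK293 cells (Homo sapiens) for inhibition; on this read-out lower numbers stand for stronger inhibition and higher numbers for weaker inhibition:
- compound 1 `CCCCCCCCCCCCCCCCCCS(=O)(=O)NCCCNCCCNCCCCNCCCN` gives 1060 nM
- compound 2 `CCCCCCCCCCCCCCCCS(=O)(=O)NCCCOCCCCOCCCN` gives 22400 nM

Of these two numbers, compound 2 has the higher at 22400 nM in this assay, and it is the weaker inhibitor, with a gap to compound 1 that lies beyond the scatter.

The next compound is compound 3 `CCCCCCCCCCCCCCCCS(=O)(=O)NCCCN(CCCN)CCCN`, which keeps the long chain and the sulfonamide of compound 2. The change is a group of 9 heavy atoms (6 carbon, 3 nitrogen; no ring) in place of a group of 10 heavy atoms (7 carbon, 1 nitrogen, 2 oxygen; no ring), on a saturated chain carbon, three bonds along the chain from a sulfonamide nitrogen. The ether-containing chain end gives way to bis(3-aminopropyl)amino, on a saturated chain carbon, three bonds along the chain from a sulfonamide nitrogen.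

Among the measured compounds shown here, no measured pair isolates this change. For the measured compounds named here, the only guide is compound 1, whose chain carries amine nitrogens and which reads 1060 nM in this assay, although it also differs from compound 2 in the length of its long chain. A moderate move toward stronger inhibition, probably beyond the scatter, is therefore expected, and the estimated size is a 5.6-fold lower number from compound 2 to compound 3 (0.75 log units; beyond the scatter) in this assay as a working figure. For compound 3 the estimated value is 4000 nM, with an expected range from 1200 nM to 13000 nM in this measurement.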

Compound 3, half-maximal inhibitory concentration: 9190 nM
The estimate for compound 3 lay 2.3-fold (0.36 log units) below the measured number; the range from low to high includes it.
By their numbers in this assay, from the lowest: compound 1; then compound 3; then compound 2.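

In this assay, among the compounds shown here, the exchange of the ether-containing chain end for bis(3-aminopropyl)amino, on a saturated chain carbon, three bonds along the chain from a sulfonamide nitrogen, gives a 2.4-fold lower number from compound 2 to compound 3 (0.39 log units; beyond the scatter) and provides the first reading of a change in one place. The step is modest but lies beyond the scatter, and since the long chain and the sulfonamide stay the same, it shows that this chain end alone can shift inhibition, with the amine-bearing group giving the stronger result. No supporting measurement is available to explain the shift.

The compounds shown leave open how the long chain and the chain end each contribute to the value of compound 1, which differs from compound 3 in more than one place. They also leave open whether the branching of bis(3-aminopropyl)amino matters, and whether another group at this position, such as a guanidine or a carboxylic acid, would move the number further in either direction.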